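Swapping Bromo for Methoxy in Compound 3

The source may hold more compounds than are shown below. What is called first, only, known or untested is meant among the compounds shown, and "the series" means these compounds.

In a functional assay on MGC-803 cells (Homo sapiens) for inhibition, read by CCK-8 assay, with a stated time of 48 h (on this read-out higher numbers stand for weaker inhibition and lower numbers for stronger inhibition), compound 1 `CCN1CCN(C(=S)SCC(=O)N(Cc2ccc(OC)cc2)c2cc(OC)c(OC)c(OC)c2)CC1` gives 9890 nM and compound 2 `COc1ccc(CN(C(=O)CSC(=S)N2CCOCC2)c2cc(OC)c(OC)c(OC)c2)cc1` gives 2370 nM. Compound 3 `COc1ccc(CN(C(=O)CSC(=S)N2CCc3cc(Br)ccc32)c2cc(OC)c(OC)c(OC)c2)cc1` reports only a limit, > 20000 nM. Compound 4 `COc1ccc(CN(C(=O)CSC(=S)N2CCc3cc(OC)ccc32)c2cc(OC)c(OC)c(OC)c2)cc1` differs from compound 3 by having methoxy in place of bromo on an aromatic carbon. The nearest evidence comes from replacing the whole group on the thiocarbonyl carbon, which gave a 4.2-fold lower number from compound 1 to compound 2 (0.62 log units; beyond the scatter), an at least 2.0-fold higher number from compound 1 to compound 3 (0.30 log units; that floor lies within the scatter) and an at least 8.4-fold higher number from compound 2 to compound 3 (0.92 log units; beyond the scatter). For the measured compounds named here, none of these steps tests a swap of bromo for methoxy, so they suggest only that changes in this region can shift this assay noticeably. A modest move toward stronger inhibition is expected, an at least 2.5-fold lower number from compound 3 to compound 4 (0.39 log units; beyond the scatter). Compound 4 is estimated at 8000 nM, within an expected range of 1500 nM to 30000 nM.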

Compound 4, half-maximal inhibitory concentration: 11700 nM
Estimate against measurement, compound 4: 1.5-fold (0.17 log units) below; the range from low to high includes it.
By their numbers in this assay, from the lowest: compound 2; then compounds 1 and 4 (each within the scatter of the next). At a limit, above all of these: compound 3.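

Compound 3 gives only a limit, not a number: the limit of > 20000 nM in this assay, at which 1 of the 4 values shown sits. Methoxy in place of bromo on this aromatic carbon gives an at least 1.7-fold lower number from compound 3 to compound 4 (0.23 log units; that floor lies within the scatter), so the true size of the change remains unknown. The 5-methoxy-2,3-dihydro-1H-indol-1-yl group in place of morpholin-4-yl gives a 4.9-fold higher number from compound 2 to compound 4 (0.69 log units; beyond the scatter), while in place of 4-ethylpiperazin-1-yl it gives a 1.2-fold higher number from compound 1 to compound 4 (0.07 log units; within the scatter).

The compounds shown leave open what an amine or a hydroxyl group on this same aromatic carbon would do. They also leave open how far methoxy truly differs from bromo here.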